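Notes on the step from compound 1 to compound 3

A few compounds are considered here, and "the series" means these few. Any claim that something is new, unique, unknown or untested is made for them only; others in the source may bear on it.

Measured so far:
- compound 1 `O=C(/C=C/c1cc(Br)c(O)c(Br)c1)Nc1cc2c(Nc3ccc(F)c(Cl)c3)ncnc2cc1O[C@H]1CCOC1` gives 25500 nM
- compound 2 `COc1cc2ncnc(Nc3ccc(F)c(Cl)c3)c2cc1NC(=O)/C=C/c1cc(OC)c(OC)c(OC)c1` gives 38200 nM

In a functional assay on PC-3 cells (Homo sapiens) for cytotoxicity, read by MTT assay, with a stated time of 72 h (a higher number here means a weaker inhibitor, a lower number a stronger inhibitor), compound 1 stands within the usual scatter of compound 2, so the two numbers cannot be ranked.

Compound 3 `COc1ccc(/C=C/C(=O)Nc2cc3c(Nc4ccc(F)c(Cl)c4)ncnc3cc2O[C@H]2CCOC2)cc1` is still unmeasured. It differs from compound 1 at one place: 4-methoxyphenyl in place of 3,5-dibromo-4-hydroxyphenyl on a double-bonded chain carbon bound to a double-bonded chain carbon with 4-methoxyphenyl in place of 3,5-dibromo-4-hydroxyphenyl on a double-bonded chain carbon bound to a double-bonded chain carbon.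

Among the measured compounds shown here, no measured pair differs in one place only, so this change has no direct precedent here. For the measured compounds named here, the only guide is the level of the series, with compound 1 at 25500 nM and compound 2 at 38200 nM as its two readings. On that basis no step beyond the scatter is expected in this assay and no firm direction can be argued. The estimated step is a 1.2-fold higher number from compound 1 to compound 3 (0.07 log units; within the scatter) and stays inside that scatter. For compound 3 the expected value is 30000 nM with an estimated range from 12000 nM to 70000 nM for the coming reading.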

Compound 3, half-maximal inhibitory concentration: 2240 nM
The estimate for compound 3 lay 13-fold (1.13 log units) above the measured number; measured number outside the range, below it.
By their numbers in this assay, from the lowest: compound 3; then compounds 1 and 2 (each within the scatter of the next).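

In this assay, the group on a double-bonded chain carbon bound to a double-bonded chain carbon proves to be a sensitive place in this series: with the rest of the structure unchanged, 4-methoxyphenyl in place of 3,5-dibromo-4-hydroxyphenyl gives an 11-fold lower number from compound 1 to compound 3 (1.06 log units; beyond the scatter). Among the compounds shown here, this is the first reading of a change at one place only, and it shows that the aryl group on this chain can move the number well beyond the scatter, which the earlier pair of values could not show. The bromine atoms, the hydroxy group and the methoxy group all change together in this single step, and no supporting measurement speaks to why the number moved.

The compounds shown leave open which of these features carries the step, a question that 4-hydroxyphenyl, 4-bromophenyl or 3,5-dibromo-4-methoxyphenyl at the same place could begin to separate. Also open, on these data alone, is whether the trend continues with other groups on this chain, such as unsubstituted phenyl or a 4-aminophenyl carrying an amine.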